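The compounds below may be only part of what the source reports. "The series", "measured", "known", "first", "only" and "open" are said of these compounds alone.

Three hydrazone-thiourea or urea compounds built on a shared core have been tested in a functional assay on SGC-7901 cells (Homo sapiens) for antiproliferative activity, read by sulforhodamine B assay, with a stated time of 72 h; on this read-out lower numbers stand for stronger inhibition and higher numbers for weaker inhibition. Compound 1 `COc1ccc(C)cc1NC(=S)N/N=C/c1ccc2ccccc2n1` reaches only the limit of the assay, > 100000 nM, which is not a number. Compound 3 `Cc1ccc(NC(=O)N/N=C/c2ccc3ccccc3n2)cc1` likewise sits at the limit, > 100000 nM, again not a number. Among the measured compounds shown here, compound 2 `S=C(N/N=C/c1ccc2ccccc2n1)Nc1ccc(Br)cc1`, which carries a 4-bromophenyl group, gives the only measured number in this assay, 69400 nM, so it stands alone among the three as the one compound for which an actual concentration could be read. The other two values, those of compound 1 and compound 3, are limits, as already noted: the limit of > 100000 nM in this assay, at which 2 of the 3 values shown sit.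

The next compound, compound 4 `S=C(N/N=C/c1ccc2ccccc2n1)Nc1ccc(Cl)cc1`, differs from compound 2 in one place: chloro in place of bromo on an aromatic carbon. For the measured compounds named here, no step between two measured compounds of this kind is available, so nothing measured tells how this exchange shifts activity. Given that the change is the smallest kind in the set, a step in this assay of no more than the usual scatter is expected in either direction, with some chance that only a limit is reported. Compound 4 is therefore estimated at 80000 nM, within 35000 nM to 180000 nM. The step from compound 2 to compound 4 is expected to be a 1.2-fold higher number from compound 2 to compound 4 (0.06 log units; within the scatter).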

Compound 4, half-maximal inhibitory concentration: 87600 nM
Beside the measured number, compound 4's estimate is 1.1-fold (0.04 log units) below it; the measured number falls inside the stated range.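

In this assay, swapping bromo for chloro on this aromatic carbon, para to a large group, gives a 1.3-fold higher number from compound 2 to compound 4 (0.10 log units; within the scatter), so the two halogens cannot be told apart at this position. Among the compounds shown here, this is the first step in the set that links two real numbers, and it shows that activity that can be read, rather than a limit, is not unique to the 4-bromophenyl compound, as the 4-chlorophenyl group in compound 4 also gives a measured concentration. Even so, both compounds remain weak, with numbers lying close to the point where this test stops giving values: the limit of > 100000 nM in this assay, at which 2 of the 4 values shown sit.

The compounds shown leave open whether a different kind of group in the same place, such as an amine, a carboxylic acid or a longer chain like propyl, would move the number clearly away from these two halogen values. They also leave open how the urea and thiourea links compare, as compound 3 differs from compound 2 and compound 4 in more than one place.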